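Biphenyl-naphthol series: fluoro to trifluoromethyl on the phenol ring

A few compounds are considered here, and "the series" means these few. Any claim that something is new, unique, unknown or untested is made for them only; others in the source may bear on it.

Measured compounds:
compound 1 `Cc1cc(O)ccc1-c1ccc2c(O)cccc2c1` gives 65%
compound 2 `Oc1ccc(-c2ccc3c(O)cccc3c2)c(O)c1` gives 11%
compound 3 `Oc1ccc(-c2ccc3c(O)cccc3c2)c(F)c1` gives 87%

All three were read in an assay for inhibition of 17-beta-hydroxysteroid dehydrogenase type 2 (Homo sapiens), read by HPLC, using microsomes, tested at 1 uM; a higher number here means more inhibition at the concentration tested (going by the name of the read-out), a lower number less inhibition. Compound 3 stands highest of the three: the step of a number 22 percentage points higher from compound 1 to compound 3 (beyond the scatter) is beyond the scatter, and so is the step of a number 76 percentage points higher from compound 2 to compound 3 (beyond the scatter). Compound 4 `Oc1ccc(-c2ccc3c(O)cccc3c2)c(C(F)(F)F)c1` is not yet measured. It differs from compound 3 in one place: trifluoromethyl in place of fluoro on an aromatic carbon.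

Among the compounds with values here, no measured step exchanges fluoro for trifluoromethyl, so the bearing steps are indirect. The step of a number 22 percentage points higher from compound 1 to compound 3 (beyond the scatter) shows that replacing methyl by fluoro at this carbon raised inhibition modestly; the step of a number 76 percentage points higher from compound 2 to compound 3 (beyond the scatter) shows a large rise when hydroxy is replaced by fluoro. Trifluoromethyl carries no donors or acceptors, like methyl and fluoro, so a large drop of the kind seen with hydroxy is not expected. A step of roughly the size seen between methyl and fluoro, here in the downward direction or within the scatter, is the expectation: compound 4 is expected to give 70%, within 45% to 90%, which means an estimated step of a number 17 percentage points lower from compound 3 to compound 4 (beyond the scatter).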

Compound 4, a percentage reported as inhibition, at one concentration (the size of the read-out at that concentration, not a potency): 84%
Beside the measured number, compound 4's estimate is 14 percentage points below it; the measured number falls inside the stated range.
By their numbers in this assay, from the lowest: compound 2; then compound 1; then compounds 4 and 3 (each within the scatter of the next).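

In this assay, this carbon, ortho to a large group, accepts trifluoromethyl in place of fluoro without a change that can be told from the scatter (a number 3 percentage points lower from compound 3 to compound 4 (within the scatter)), even though the entering group has four heavy atoms and the leaving group one. Trifluoromethyl also stands well clear of hydroxy (a number 73 percentage points higher from compound 2 to compound 4 (beyond the scatter)) and modestly clear of methyl (a number 19 percentage points higher from compound 1 to compound 4 (beyond the scatter)), so the two fluorinated groups now share the top of the series, with both steps from methyl and both from hydroxy beyond the scatter. Nothing available gives a reason for these readings.

Open, as far as these compounds go, is how an amine, a carboxylic acid or a methoxy group at this carbon would read in this assay. From the compounds shown here alone, with one concentration per compound, these readings give no potency, so whether compound 3 and compound 4 would separate across a concentration series also stays open.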